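Taking the chloro group away from compound 3

A few compounds are considered here, and "the series" means these few. Any claim that something is new, unique, unknown or untested is made for them only; others in the source may bear on it.

For the measured compounds named here, in a functional assay (muscle tissue) with Cavia porcellus as the target (a higher number here means that more compound is needed for the effect, a lower number that less compound is needed), compound 3 `COC(=O)C1=C(C)N=C(C)/C(=C(\O)OC)C1c1cc([N+](=O)[O-])ccc1Cl` gives 30.2 nM, the highest number of the three measured so far. Compound 1 `COC(=O)C1=C(C)N=C(C)/C(=C(\O)OC)C1c1ccccc1Cl` gives 2.19 nM and compound 2 `COC(=O)C1=C(C)N=C(C)/C(=C(\O)OC)C1c1ccccc1C(F)(F)F` gives 1.51 nM. The exchange of chloro for trifluoromethyl between these two is a 1.5-fold lower number from compound 1 to compound 2 (0.16 log units; within the scatter).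

Compound 4 `COC(=O)C1=C(C)N=C(C)/C(=C(\O)OC)C1c1cccc([N+](=O)[O-])c1` arises from compound 3 through a single change: hydrogen in place of chloro on an aromatic carbon, ortho to a large group and para to a nitro group (hydrogen in place of chloro on an aromatic carbon). Going by the values given here, no measured step removes a chloro group on its own, so the evidence is indirect. The closest evidence is the nitro step, a 14-fold higher number from compound 1 to compound 3 (1.14 log units; beyond the scatter), made on a compound that keeps its chloro. Compound 4 retains the nitro but lacks the chloro, so only part of that large rise is expected to remain. The expected change is a 3.8-fold lower number from compound 3 to compound 4 (0.58 log units; beyond the scatter), a moderate move towards a lower number, though it is poorly constrained. For compound 4 the estimated value is 8 nM, with an expected range from 2 nM to 30 nM.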

Compound 4, half-maximal effective concentration: 3.98 nM
Compound 4: middle estimate off by 2.0-fold (0.30 log units), on the high side, within the range that was stated.
By their numbers in this assay, from the lowest: compounds 2, 1 and 4 (each within the scatter of the next, the first and the last beyond it); then compound 3.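

Removing the chloro group outright, with the nitro group kept in place, gives a 7.6-fold lower number from compound 3 to compound 4 (0.88 log units; beyond the scatter). For the compounds shown here, until then this carbon had been seen only with a substituent on it, where the exchange of chloro for trifluoromethyl gave a 1.5-fold lower number from compound 1 to compound 2 (0.16 log units; within the scatter), so the new step is the first to show that a hydrogen at this carbon can read differently from chloro, at least while the nitro group is present. No measurement available here explains why the number falls.

The compounds shown leave open whether losing the chloro group would change the number in the same way without the nitro group, and whether the nitro step itself depends on the chloro group. They also leave open how a methoxy group or an amine on this carbon would compare with chloro and hydrogen.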